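Dropping the methoxy group from compound 2

This account rests on a few compounds, and the source may have more. Where it says the series, first, only, none or still open, it means among the compounds named here.

Three compounds share one core and differ in a single group on an aromatic carbon, which is methyl, nitro or chloro. In a functional assay on RS4-11 cells (Homo sapiens) for inhibition, read by CCK-8 assay, with a stated time of 48 h, tested at 20 uM (on this read-out lower numbers stand for less inhibition of growth and higher numbers for more inhibition of growth at the one concentration tested), compound 1 `COc1ccc(Cc2nnc(NC(=O)/C(C#N)=C/c3ccccc3OS(=O)(=O)c3ccc(C)cc3)s2)cc1` gives 70%, compound 2 `COc1ccc(Cc2nnc(NC(=O)/C(C#N)=C/c3ccccc3OS(=O)(=O)c3ccc([N+](=O)[O-])cc3)s2)cc1` gives 70% and compound 3 `COc1ccc(Cc2nnc(NC(=O)/C(C#N)=C/c3ccccc3OS(=O)(=O)c3ccc(Cl)cc3)s2)cc1` gives 79%. Compound 2 stands level with compound 1, and none of the three numbers is separated from another beyond the scatter. The measured steps are no change at the digits printed from compound 1 to compound 2 (within the scatter), a number 9 percentage points higher from compound 1 to compound 3 (within the scatter) and a number 9 percentage points higher from compound 2 to compound 3 (within the scatter).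

Compound 4 `N#C/C(=C\c1ccccc1OS(=O)(=O)c1ccc([N+](=O)[O-])cc1)C(=O)Nc1nnc(Cc2ccccc2)s1` keeps the nitro group of compound 2 but changes another place: hydrogen in place of methoxy on an aromatic carbon. In words, 4-methoxybenzyl becomes benzyl. Going by the values given here, no measured step touches this place, so the three steps bear on it only indirectly, and the data hold no direct test of losing the methoxy group. The largest of them, a number 9 percentage points higher from compound 2 to compound 3 (within the scatter), sets the only available scale, and no shift beyond the scatter is expected in this assay. The expected change is a number 2 percentage points lower from compound 2 to compound 4 (within the scatter). Compound 4 is estimated at 68%, with an expected range of 52% to 82%.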

Compound 4, percent growth inhibition at one concentration: 57%
For compound 4 the middle estimate is 11 percentage points above the measured one, within the range that was stated.
By their numbers in this assay, from the lowest: compound 4; then compounds 1, 2 and 3 (each within the scatter of the next).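

Hydrogen in place of methoxy, with 4-methoxybenzyl becoming benzyl, gives a number 13 percentage points lower from compound 2 to compound 4 (beyond the scatter) in this assay and is the only step shown that lies beyond the scatter. Going by these compounds alone, the methoxy position therefore registers on this read-out, whereas the swaps among methyl, nitro and chloro separated no pair of compounds, although this rests on a single pair carrying the nitro group. Nothing in the data gives a reason for this step.

As far as these compounds go, it remains open whether losing the methoxy group has the same effect when methyl or chloro replaces the nitro group. The compounds shown also leave open how a hydroxyl group, an amine, a fluoro group or a longer ethoxy chain would compare with methoxy at this position.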